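The compounds below may be only part of what the source reports. "The series", "measured", "known", "first", "only" and "open" are said of these compounds alone.

The three measured compounds, all tested in a functional assay on the whole organism (strain albino) for inhibition, with Rattus norvegicus as the target, read by paw edema, with a stated time of 3 h, at a dose of 0.28 mmol/kg by the oral route; a lower number here means less inhibition, a higher number more inhibition at the dose given (going by the name of the read-out):

Compound 1 `C=CCn1c(SCC(=O)c2ccccc2)nnc1-c1ccc(OC)c(OC)c1` gives 64%.
Compound 2 `C=CCn1c(SCC(=O)c2ccccc2)nnc1-c1ccc(OC)cc1` gives 63%.
Compound 3 `CCn1c(SC/C(=N/O)c2ccccc2)nnc1-c1ccc(OC)cc1` gives 75%.

Compound 1 and compound 2 differ in one place: hydrogen in place of methoxy on an aromatic carbon. This change made a step of a number 1 percentage points lower from compound 1 to compound 2 (within the scatter) in this assay. Compound 3 stands highest of the three, beyond the scatter from compound 1 and from compound 2; how its core differs from the core of compound 1 is not broken down here.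

Compound 4 `CCn1c(SC/C(=N/O)c2ccccc2)nnc1-c1ccccc1` has not yet been measured. It differs from compound 3 by hydrogen in place of methoxy on an aromatic carbon. Among the measured compounds shown here, this is the same kind of change as the one between compound 1 and compound 2, but the place is not the same: there the hydrogen entered ortho to a methoxy group and meta to a large group, here it enters para to a large group. The step expected in this assay is a number 3 percentage points lower from compound 3 to compound 4 (within the scatter), because the earlier step of a number 1 percentage points lower from compound 1 to compound 2 (within the scatter) stayed within the scatter. Compound 4 is therefore expected to give about 72%, with a likely range from 60% to 82%.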

Compound 4, a percentage reported as inhibition, in the whole organism at one dose (the size of the read-out at that dose, not a potency): 72%
Estimate against measurement, compound 4: no gap at the digits printed; the range from low to high includes it.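

Putting hydrogen in place of methoxy, the change from 4-methoxyphenyl to phenyl, gives a number 3 percentage points lower from compound 3 to compound 4 (within the scatter) in this assay. Set beside the same change on the other core, the two steps do not differ by more than the usual scatter: the same change on two cores in this assay, a number 1 percentage points lower (within the scatter) from compound 1 to compound 2 and a number 3 percentage points lower (within the scatter) from compound 3 to compound 4, 2 percentage points apart, within the scatter of two such steps In these two pairs, then, the change carries from one core to the other without a step beyond the scatter on either, but that is all they show: the change sits at a different place on the ring in each pair, the evidence comes from a single dose in a single assay, and two cores give no rule for any third core.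

The compounds shown leave open whether a different group on this ring, such as a chlorine atom, a hydroxyl or an amine, would give a step beyond the scatter. They also leave open what a longer chain in place of the ethyl group of compound 4 would do.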